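The source may report more compounds than this note shows. Statements on the series, on what has been measured and on what is new or still open speak of the compounds shown alone.

In an ADME assay on the whole organism (plasma, strain CD) for pharmacokinetics, with Rattus norvegicus as the target, at a dose of 5 mg/kg by the oral route (a higher number here means more compound in the circulation at the dose given, a lower number less compound in the circulation), compound 1 (`O=C(NCCO)c1c(O)c2ncc(Cc3ccc(F)cc3)cc2[nH]c1=O`) gives 3060 ng.h/mL and compound 2 (`C[C@@H](CO)NC(=O)c1c(O)c2ncc(Cc3ccc(F)cc3)cc2n(C)c1=O`) gives 22600 ng.h/mL as its result. Within the data shown here, compound 2 therefore holds the higher of only two numbers, and the gap between them lies beyond the usual scatter. Compound 3 (`Cn1c(=O)c(C(=O)NCCO)c(O)c2ncc(Cc3ccc(F)cc3)cc21`) has not yet been measured. It differs from compound 2 by one small edit (hydrogen in place of methyl on a saturated chain carbon bound to an amide-type nitrogen and a saturated chain carbon) with hydrogen in place of methyl on a saturated chain carbon bound to an amide-type nitrogen and a saturated chain carbon, so 1-(hydroxymethyl)ethyl becomes 2-hydroxyethyl. Among the measured compounds shown here, no measured pair shows this change alone, so any forecast is a judgement. The estimated step of a 1.9-fold lower number from compound 2 to compound 3 (0.27 log units; within the scatter) is a moderate fall, expected to lie close to the edge of the scatter. Compound 3 is expected at 12000 ng.h/mL with an estimated range (4000 ng.h/mL to 30000 ng.h/mL).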

Compound 3, area under the concentration-time curve: 22800 ng.h/mL
Beside the measured number, compound 3's estimate is 1.9-fold (0.28 log units) below it, and the stated range covers the measured number.
By their numbers in this assay, from the lowest: compound 1; then compounds 2 and 3 (each within the scatter of the next).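

In this assay, hydrogen in place of methyl on the saturated chain carbon, which turns 1-(hydroxymethyl)ethyl into 2-hydroxyethyl, gives a 1.0-fold higher number from compound 2 to compound 3 (0.00 log units; within the scatter), so this methyl makes no difference that can be told from scatter. Compound 3 also forms a one-place pair with compound 1, where methyl in place of hydrogen on an aromatic nitrogen gives a 7.5-fold higher number from compound 1 to compound 3 (0.87 log units; beyond the scatter), so with the 2-hydroxyethyl chain held constant, the large step follows the methyl on that nitrogen and not the one on the chain. Nothing measured here gives a cause for either step.

The compounds shown leave open whether a longer chain, or an amine or a carboxylic acid in place of the chain's hydroxyl, would keep the number this high. They also leave open whether ethyl on the aromatic nitrogen would match methyl there.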